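Swapping a para ethoxy for fluoro on the anilino ring

The source may report more compounds than this note shows. Statements on the series, on what has been measured and on what is new or still open speak of the compounds shown alone.

Compound 2 `CCOc1ccc(NC2=C(C(=O)c3ccccc3)C(c3ccc(Br)cc3)N(CCCn3ccnc3)C2=O)cc1`: 20000 nM
Compound 1 `NC1=C(C(=O)c2ccccc2)C(c2ccc(Br)cc2)N(CCCn2ccnc2)C1=O`: 169000 nM

In a functional assay on NCI-H1299 cells (Homo sapiens) for antiproliferative activity, read by MTT assay, with a stated time of 72 h (a higher number here means a weaker inhibitor, a lower number a stronger inhibitor), compound 2 gives the lowest of the two numbers; compound 1 stands nearest, at a number that an 8.5-fold lower number from compound 1 to compound 2 (0.93 log units; beyond the scatter) shows is higher, that step being the only measured one. Compound 3 `O=C(C1=C(Nc2ccc(F)cc2)C(=O)N(CCCn2ccnc2)C1c1ccc(Br)cc1)c1ccccc1` is not yet measured. It differs from compound 2 by fluoro in place of ethoxy on an aromatic carbon. Among the measured compounds shown here, no measured step touches this ring position, so the one measured step does not bear on it directly. Compound 3 is therefore expected to land near compound 2, with a 1.5-fold higher number from compound 2 to compound 3 (0.18 log units; within the scatter) as the estimated step. Compound 3 is estimated at 30000 nM, between 10000 nM and 90000 nM.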

Compound 3, half-maximal inhibitory concentration: 25400 nM
For compound 3 the middle estimate is 1.2-fold (0.07 log units) above the measured one; the range from low to high includes it.
By their numbers in this assay, from the lowest: compounds 2 and 3 (each within the scatter of the next); then compound 1.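

In this assay, a 1.3-fold higher number from compound 2 to compound 3 (0.10 log units; within the scatter) shows that ethoxy and fluoro on this aromatic carbon cannot be told apart, although fluoro has one heavy atom against three. The gain from putting an aryl group on the amine nitrogen also holds with fluoro, a 6.7-fold lower number from compound 1 to compound 3 (0.82 log units; beyond the scatter), so it does not depend on ethoxy alone. Nothing measured here explains why the two groups read alike. Still open, from the compounds shown here alone, is whether an amine, a carboxylic acid or a longer alkoxy chain on this aromatic carbon would also read alike.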